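This account rests on a few compounds, and the source may have more. Where it says the series, first, only, none or still open, it means among the compounds named here.

- Compound 1 `C[C@H]1O[C@@H]2C[C@@H](O)[C@@]1(O)c1c2c(O)c(C(N)=O)c2ncoc12` gives 5700 nM 
- Compound 2 `C[C@H]1O[C@@H]2C[C@@H](O)[C@@]1(O)c1c2c(O)c(C(N)=O)c2nc([C@@H](O)CO)oc12` gives 4800 nM 

Among the measured compounds shown here, in a functional assay on 4T1 cells (Mus musculus) for inhibition, read by CCK-8 assay, with a stated time of 72 h (on this read-out higher numbers stand for weaker inhibition and lower numbers for stronger inhibition), compound 2 reads 4800 nM and sits level with compound 1, the only other compound measured so far, so the two cannot be ranked. Compound 3 `C[C@H]1O[C@@H]2C[C@@H](O)[C@@]1(O)c1c2c(O)c(C(N)=O)c2nc([C@@H](O)[C@@H](O)CO)oc12` differs from compound 2 by hydroxymethyl in place of hydrogen on a saturated chain carbon bound to an oxygen on a saturated carbon and a saturated chain carbon and the same difference can be read as 1,2-dihydroxyethyl to 1,2,3-trihydroxypropyl. For the measured compounds named here, only one measured step bears on this change. It is a 1.2-fold lower number from compound 1 to compound 2 (0.07 log units; within the scatter) and it shows that placing the whole 1,2-dihydroxyethyl group on an aromatic carbon left the number within the scatter. No step beyond the scatter, in either direction, is therefore expected from the further hydroxymethyl. The estimate means a 1.0-fold higher number from compound 2 to compound 3 (0.02 log units; within the scatter) as the expected step. For compound 3 the expected value is 5000 nM with an estimated range from 2500 nM to 10000 nM in this assay.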

Compound 3, half-maximal inhibitory concentration: 4300 nM
The estimate for compound 3 lay 1.2-fold (0.07 log units) above the measured number; the range from low to high includes it.
By their numbers in this assay, from the lowest: compounds 3, 2 and 1 (each within the scatter of the next).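

In this assay, hydroxymethyl on the saturated chain carbon leaves the number within the scatter, with a 1.1-fold lower number from compound 2 to compound 3 (0.05 log units; within the scatter). The earlier compounds shown here showed this only for 1,2-dihydroxyethyl, whereas the longer 1,2,3-trihydroxypropyl group, taken whole in place of hydrogen on the aromatic carbon, also stays within the scatter, with a 1.3-fold lower number from compound 1 to compound 3 (0.12 log units; within the scatter), so compounds 1, 2 and 3 cannot be ranked. No supporting measurement is available to explain this flat result.

These three compounds cover only hydrogen and two hydroxyl-bearing chains, so they cannot show whether this place tolerates every substituent or simply has little influence on the number. An amine or a carboxylic acid on the chain, or a longer chain without hydroxyl groups, could still move the number beyond the scatter.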